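Acetylation of a diol in an MCF7 cytotoxicity series

This account rests on a few compounds, and the source may have more. Where it says the series, first, only, none or still open, it means among the compounds named here.

Working notes on a small set run in a functional assay on MCF7 cells (Homo sapiens) for cytotoxicity, read by resazurin assay; on this read-out lower numbers stand for stronger inhibition and higher numbers for weaker inhibition. Compound 1 `C[C@]1([C@@H]2Cc3cc(C(N)=O)cc(Cl)c3O2)CCC(=O)O1` reaches only the assay limit, giving > 169000 nM. Compound 2 `C/C(=C/[C@H](O)[C@H](O)c1ccccc1)CCO` likewise stops at a limit, > 225000 nM, so it stands among values that are limits rather than numbers, as the limit of > 225000 nM in this assay, at which 1 of the 2 values shown sits, records. Compound 3 `CC(=O)OCC/C(C)=C\[C@H](O)[C@H](O)c1ccccc1` differs from compound 2 by acetyl in place of hydrogen on an oxygen on a saturated carbon. Among the measured compounds shown here, no measured step of this kind exists here, so no change beyond the scatter in this assay is expected, in either direction. Compound 3 is therefore expected at 300000 nM, within 100000 nM to 1000000 nM. The expected step is a step that the limit leaves unreadable from compound 2 to compound 3, essentially flat.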

Compound 3, half-maximal inhibitory concentration: > 189000 nM
Compound 3 was reported as a limit (the forecaster's own chance of this, stated with the estimate: 85%); the middle value is on the limit's open side.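

Compound 3 gives > 189000 nM, which is a limit. Compound 2 also stands at a limit, so no step can be read between compound 2 and compound 3. As far as these compounds go, whether acetyl in place of hydrogen on this oxygen changes cytotoxicity remains open.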